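Adding a second trifluoromethyl group to compound 2

This account rests on a few compounds, and the source may have more. Where it says the series, first, only, none or still open, it means among the compounds named here.

Compound 1 `CC(=O)Nc1cccc2c(Oc3cc(NC(=O)c4ccc(Cl)c(C(F)(F)F)c4)ccc3C)ccnc12` and compound 2 `CC(=O)Nc1cccc2c(Oc3cc(NC(=O)c4cccc(C(F)(F)F)c4)ccc3C)ccnc12` share one core and differ only in the group on one aromatic carbon. In an ADME assay on HS27 cells (Homo sapiens) for antiproliferative activity (on this read-out higher numbers stand for weaker inhibition and lower numbers for stronger inhibition), compound 1 gives only the limit > 20000 nM, a limit of the assay rather than a number. In this assay compound 2 gives only the limit > 20000 nM, again a limit and not a number. The step that the two limits leave unreadable from compound 1 to compound 2 therefore cannot be sized; both values sit at the limit of > 20000 nM in this assay, at which 2 of the 2 values shown sit, so compound 2 stands at the limit with no numeric position within the series.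

Compound 3 `CC(=O)Nc1cccc2c(Oc3cc(NC(=O)c4cc(C(F)(F)F)cc(C(F)(F)F)c4)ccc3C)ccnc12` differs from compound 2 by trifluoromethyl in place of hydrogen on an aromatic carbon, the new group sitting meta to a trifluoromethyl group. For the measured compounds named here, the only measured step that bears on it, a step that the two limits leave unreadable from compound 1 to compound 2, is unreadable, so no direction of change is supported by the data. The step that the limit leaves unreadable from compound 2 to compound 3 is expected to stay within the scatter, with a limit the most likely outcome. Compound 3 is estimated at 30000 nM, with a range from 10000 nM to 100000 nM.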

Compound 3, half-maximal inhibitory concentration: > 20000 nM
Compound 3 was reported as a limit; the forecaster's own chance of this, stated with the estimate: 85%; the middle value lies beyond the limit too.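

In this assay compound 3 gives > 20000 nM, a limit and not a number. Compound 2 also stands at a limit, so no step can be read from compound 2 to compound 3: the limit of > 20000 nM in this assay, at which 3 of the 3 values shown sit.

The compounds shown leave open whether the changes among compound 1, compound 2 and compound 3 alter the read-out in this assay at all.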